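The source may report more compounds than this note shows. Statements on the series, on what has been measured and on what is new or still open speak of the compounds shown alone.

Three measured compounds share one core and differ only in the aromatic ring that hangs from the amide nitrogen through a saturated chain carbon. Compound 1 `Cc1ccccc1CNC(=O)c1nc(-c2ccc(F)cc2)n(CC[C@@H](O)C[C@@H](O)CC(=O)O)c1C1CC1` carries a 2-methylphenyl there, and in a physicochemical assay for lipophilicity, using the shake flask method, at pH 7.4 (a lower number here means a more polar compound, a higher number a more lipophilic compound), compound 1 gives 0.44. Compound 2 `O=C(O)C[C@H](O)C[C@H](O)CCn1c(-c2ccc(F)cc2)nc(C(=O)NCc2cccc(F)c2)c1C1CC1` gives 0.51 in this assay, and compound 3 `Cc1cccc(CNC(=O)c2nc(-c3ccc(F)cc3)n(CC[C@@H](O)C[C@@H](O)CC(=O)O)c2C2CC2)c1` gives 0.47. Compound 1 stands lowest of the three numbers, but the steps of a number 0.07 log units higher from compound 1 to compound 2 (within the scatter) and a number 0.03 log units higher from compound 1 to compound 3 (within the scatter) both lie within the scatter, as does a number 0.04 log units lower from compound 2 to compound 3 (within the scatter), so the three compounds cannot be placed in any order on these data.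

Compound 4 `O=C(O)C[C@H](O)C[C@H](O)CCn1c(-c2ccc(F)cc2)nc(C(=O)NCc2ccccc2)c1C1CC1` is not yet measured. Its difference from compound 1 is hydrogen in place of methyl on an aromatic carbon. Among the measured compounds shown here, no measured step removes a methyl outright: the step from compound 1 to compound 3 moves the methyl to another position, and the step from compound 2 to compound 3 exchanges fluoro for methyl, and each stayed within the scatter. On that basis the step to compound 4 is expected to be small, leaning lower, and it may well fall within the scatter itself; the expected step is a number 0.29 log units lower from compound 1 to compound 4 (within the scatter). For compound 4 the estimate in this assay is 0.15, with a range from -0.25 to 0.5.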

Compound 4, distribution coefficient: 0.03
Compound 4: the middle estimate sits 0.12 log units above what was measured, within the range that was stated.
By their numbers in this assay, from the lowest: compound 4; then compounds 1, 3 and 2 (each within the scatter of the next).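

In this assay the ring with no substituent stands apart: there is a number 0.41 log units lower from compound 1 to compound 4 (beyond the scatter) and a number 0.44 log units lower from compound 3 to compound 4 (beyond the scatter) when methyl gives way to hydrogen, and a number 0.48 log units lower from compound 2 to compound 4 (beyond the scatter) when fluoro does. This ring looked indifferent while only the kind and place of its substituent varied among compound 1, compound 2 and compound 3, but it matters for this read-out once the substituent is gone altogether: what counts here is having a methyl or a fluoro on the ring at all, while which of the two it is, and where the methyl sits, could not be told apart. Nothing given here explains why the step is this large.

Among the compounds shown, only methyl and fluoro stand against hydrogen on this ring, so it stays open whether a chloro, a methoxy or a longer chain such as ethyl would fall with compound 1, compound 2 and compound 3 or with compound 4. Also open, as far as these compounds go, is whether a ring carrying two methyl groups would move the number any further, and whether the same step would appear on a different core.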